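The source may report more compounds than this note shows. Statements on the series, on what has been measured and on what is new or still open speak of the compounds shown alone.

Among the measured compounds shown here, compound 3 `O=C(/C=C/c1ccccc1Cl)NNC(=O)c1ccc2c(c1)OCCO2` carries a 2-chlorophenyl group; in an ADME assay on cells (Macrophage) for cytotoxicity, read by MTT assay, with a stated time of 24 h (on this read-out lower numbers stand for higher toxicity in this test and higher numbers for lower toxicity in this test), compound 3 gives 285000 nM, the second highest of the three numbers measured so far. Compound 1 `COc1cccc(/C=C/C(=O)NNC(=O)c2ccc3c(c2)OCCO3)c1` gives 398000 nM, and compound 2 `O=C(/C=C/c1ccc(Br)cc1)NNC(=O)c1ccc2c(c1)OCCO2` gives 259000 nM. The steps among them, a 1.5-fold lower number from compound 1 to compound 2 (0.19 log units; within the scatter), a 1.4-fold lower number from compound 1 to compound 3 (0.15 log units; within the scatter) and a 1.1-fold higher number from compound 2 to compound 3 (0.04 log units; within the scatter), all lie within the scatter, so the three groups tried so far are not told apart on these numbers. Compound 4 `COc1ccccc1/C=C/C(=O)NNC(=O)c1ccc2c(c1)OCCO2` differs from compound 3 by methoxy in place of chloro on an aromatic carbon. For the measured compounds named here, no measured step swaps exactly these two groups at this place. Going by the values given here, the one step that brings a methoxy group in or out, a 1.4-fold lower number from compound 1 to compound 3 (0.15 log units; within the scatter), is the closest guide, and it stayed within the scatter, as did every other step in the set. The expected step is therefore a 1.2-fold higher number from compound 3 to compound 4 (0.06 log units; within the scatter), within the scatter and in no firm direction. Compound 4 is estimated at 330000 nM in this assay, with a range from 180000 nM to 600000 nM.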

Compound 4, half-maximal cytotoxic concentration: 312000 nM
The estimate for compound 4 lay 1.1-fold (0.02 log units) above the measured number; measured number inside the range.
By their numbers in this assay, from the lowest: compounds 2, 3, 4 and 1 (each within the scatter of the next).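

Methoxy in place of chloro on an aromatic carbon, ortho to a large group, can now be read as a direct swap: in this assay it gives a 1.1-fold higher number from compound 3 to compound 4 (0.04 log units; within the scatter) and so does not tell the two groups apart. The 2-methoxyphenyl group also stays within the scatter of the other two groups, with a 1.2-fold higher number from compound 2 to compound 4 (0.08 log units; within the scatter) and with a 1.3-fold lower number from compound 1 to compound 4 (0.11 log units; within the scatter) on the comparison of 2-methoxyphenyl and 3-methoxyphenyl, so these compounds do not separate the two methoxyphenyl groups either. No outside data bear on this result.

The phenyl groups shown carry only chloro, bromo or methoxy, so the effect of an amine, a carboxylic acid or a longer alkoxy chain there remains open. On these data alone, whether any group on this phenyl can produce a step beyond the scatter also remains open.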